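Sulfonyl substituent variation on the chromone enaminone series

The compounds below may be only part of what the source reports. "The series", "measured", "known", "first", "only" and "open" are said of these compounds alone.

Three compounds sharing the core of compound 1 `NS(=O)(=O)c1ccc(N/C=C\C(=O)c2cc3ccccc3oc2=O)cc1` have been measured in a functional assay on T47D cells (Homo sapiens) for cytotoxicity, read by sulforhodamine B assay, with a stated time of 48 h; a higher number here means a weaker inhibitor, a lower number a stronger inhibitor. Compound 1 gives 109000 nM. Compound 2 `Cc1noc(NS(=O)(=O)c2ccc(N/C=C\C(=O)c3cc4ccccc4oc3=O)cc2)c1C` gives 68400 nM, and compound 3 `Cc1nnc(NS(=O)(=O)c2ccc(N/C=C\C(=O)c3cc4ccccc4oc3=O)cc2)s1` gives 94000 nM. Compound 2 holds the lowest of the three numbers, but its neighbours sit close: a 1.4-fold higher number from compound 2 to compound 3 (0.14 log units; within the scatter) and a 1.6-fold lower number from compound 1 to compound 2 (0.20 log units; within the scatter), with a 1.2-fold lower number from compound 1 to compound 3 (0.06 log units; within the scatter) completing the set, all within the scatter. On these numbers, what sits on the sulfonamide nitrogen has made no difference that can be told apart from repeat variation.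

Compound 4 `Nc1ccc(S(=O)(=O)c2ccc(N/C=C\C(=O)c3cc4ccccc4oc3=O)cc2)cc1` goes one step further: 4-aminophenyl in place of (3,4-dimethyl-1,2-oxazol-5-yl)amino on a sulfonyl sulfur. Among the measured compounds shown here, no measured step matches this change, since every earlier step kept the sulfonamide nitrogen and only exchanged the group on it. The three steps shown are all small, so the expectation for compound 4 is a number close to the others, with no change beyond the scatter: a 1.2-fold higher number from compound 2 to compound 4 (0.09 log units; within the scatter). In this assay compound 4 is estimated at 85000 nM, expected between 35000 nM and 200000 nM.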

Compound 4, half-maximal inhibitory concentration: 91900 nM
Beside the measured number, compound 4's estimate is 1.1-fold (0.03 log units) below it; the range from low to high includes it.
By their numbers in this assay, from the lowest: compounds 2, 4, 3 and 1 (each within the scatter of the next).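

Placing 4-aminophenyl directly on the sulfonyl sulfur removes the sulfonamide nitrogen itself, a larger change than exchanging the group on that nitrogen, yet the number stays within the scatter of all three earlier compounds (a 1.3-fold higher number from compound 2 to compound 4 (0.13 log units; within the scatter); a 1.0-fold lower number from compound 3 to compound 4 (0.01 log units; within the scatter); a 1.2-fold lower number from compound 1 to compound 4 (0.07 log units; within the scatter)). Among these four compounds, the sulfonamide nitrogen is therefore not needed to hold the number in this range in this assay. The flat response now covers both the group on that nitrogen and the replacement of the nitrogen-linked group by an aromatic ring bound to sulfur.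

From the compounds shown here alone, it remains open whether a carboxylic acid, a tertiary amine or a longer alkyl chain on the sulfonyl sulfur would give a step beyond the scatter. Changes to the shared core also remain untested in the compounds shown here. No supporting measurement is available to explain this flat response.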